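A few compounds are considered here, and "the series" means these few. Any claim that something is new, unique, unknown or untested is made for them only; others in the source may bear on it.

Measured in a physicochemical assay for permeability; a higher number here means that the compound crosses the layer faster, a lower number that the compound crosses the layer more slowly:

- compound 1 `Oc1ccc(NC2=NCCC3(CCCCC3)S2)cc1`: 1.72 10^-6 cm/s
- compound 2 `c1ccc(NC2=NCCC3(CCCCC3)S2)cc1`: 1.81 10^-6 cm/s

Of the compounds shown here, two measured so far, one step between them. Going by the values given here, the only measured step, a 1.1-fold higher number from compound 1 to compound 2 (0.02 log units; within the scatter), lies within the scatter, so compound 2 and compound 1 cannot be told apart in this assay; compound 2 simply sits at the level both compounds share.

Compound 3 `Cc1ccc(NC2=NCCC3(CCCCC3)S2)cc1` differs from compound 2 by methyl in place of hydrogen on an aromatic carbon.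

Among the compounds with values here, the one step that bears on this change is the one from compound 1 to compound 2, where hydroxy was exchanged for hydrogen on an aromatic carbon without moving the number beyond the scatter. Within the data shown here, the group entering now carries no hydrogen-bond donors or acceptors, and the series gives no example in which a change on this aromatic carbon has shifted the number. A step in this assay of no more than the scatter is therefore expected, if anything a slight rise, a 1.2-fold higher number from compound 2 to compound 3 (0.08 log units; within the scatter).

For compound 3 the estimate in this assay is 2.2 10^-6 cm/s, with a range from 1.3 10^-6 cm/s to 3.7 10^-6 cm/s.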

Compound 3, apparent permeability: 5.67 10^-6 cm/s
The estimate for compound 3 lay 2.6-fold (0.41 log units) below the measured number, outside the stated range (above it).
By their numbers in this assay, from the lowest: compounds 1 and 2 (each within the scatter of the next); then compound 3.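

In this assay, this place on an aromatic carbon, para to a large group, proves able to move the number: methyl in place of hydrogen gives a 3.1-fold higher number from compound 2 to compound 3 (0.50 log units; beyond the scatter), whereas the exchange of hydroxy for hydrogen gave only a 1.1-fold higher number from compound 1 to compound 2 (0.02 log units; within the scatter), within the scatter. Methyl in place of hydroxy gives a step of similar size, a 3.3-fold higher number from compound 1 to compound 3 (0.52 log units; beyond the scatter), so among these three compounds methyl stands apart, while hydrogen and hydroxy cannot be told apart. Nothing at hand accounts for a single added carbon shifting the number when the earlier exchange at the same place did not.

Still open, as far as these compounds go, is whether the rise belongs to methyl alone or continues with ethyl or a longer chain, and how methoxy, chlorine, an amine or a carboxylic acid would read at this place. Going by these compounds alone, also open is whether methyl on another carbon of this ring, or on a different core, would give a step of this size, since the series so far holds only one example of the change.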